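Benzyl Ether to Hexyl Ether in a Hydroxyurea Series

A few compounds are considered here, and "the series" means these few. Any claim that something is new, unique, unknown or untested is made for them only; others in the source may bear on it.

Compound 1, `NC(=O)N(O)CC1=Cc2cc(OCc3ccccc3)ccc2OC1`, is the reference point of this small set. Going by the values given here, in an assay (Cavia porcellus) for inhibition of Polyunsaturated fatty acid 5-lipoxygenase (Homo sapiens) (on this read-out higher numbers stand for weaker inhibition and lower numbers for stronger inhibition), compound 1 gives 380 nM, the lowest of the two numbers known so far. Among the compounds with values here, its only measured neighbour is compound 2, `NC(=O)N(O)CC1=Cc2cc(OCc3ccc(C(F)(F)F)cc3)ccc2OC1`, which in this assay gives 490 nM; the step of a 1.3-fold higher number from compound 1 to compound 2 (0.11 log units; within the scatter) stays within the scatter, so the two compounds cannot be told apart on this read-out.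

Compound 3, `CCCCCCOc1ccc2c(c1)C=C(CN(O)C(N)=O)CO2`, departs from compound 1 in a different way: pentyl in place of phenyl on a saturated chain carbon bound to an oxygen on an aromatic ring. Within the data shown here, no measured step mirrors this exchange of a ring for a chain; the one step known, trifluoromethyl in place of hydrogen on an aromatic carbon, shows only that a change to the benzyloxy group left the number where it was. On that thin basis no movement beyond the scatter is expected from compound 1 to compound 3, though the uncertainty is wider than for a simple ring substitution. Compound 3 is therefore expected to give about 500 nM in this assay, within 150 nM to 1700 nM, a step of a 1.3-fold higher number from compound 1 to compound 3 (0.12 log units; within the scatter).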

Compound 3, half-maximal inhibitory concentration: 340 nM
Beside the measured number, compound 3's estimate is 1.5-fold (0.17 log units) above it; the measured number falls inside the stated range.
By their numbers in this assay, from the lowest: compounds 3, 1 and 2 (each within the scatter of the next).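

In this assay, the change from benzyloxy to hexyloxy gives a 1.1-fold lower number from compound 1 to compound 3 (0.05 log units; within the scatter), so this read-out does not separate the two compounds even though the phenyl ring itself has gone. The earlier step showed only that a trifluoromethyl on that ring left the number within the scatter, with the ring still in place; compound 3 adds that, for this one chain, an aromatic ring at this position is not required for a number in the range of compound 1, and the pentyl that enters in place of phenyl serves equally well on this read-out. No measurement on hand speaks to why a ring and an open chain read alike here.

What the compounds shown leave open is how far this indifference extends: a shorter chain, a longer chain or a branched chain could each still move the number away from that of compound 1. Nor do they say whether a chain carrying an amine, a hydroxyl or a carboxylic acid at this position would stay within the scatter of compound 3.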